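Whole-organism inhibition: from dimethylamino to methylpiperazinyl

A few compounds are considered here, and "the series" means these few. Any claim that something is new, unique, unknown or untested is made for them only; others in the source may bear on it.

Measured so far:
compound 1, `C/N=C(/NC#N)NCCCCn1nc(N(C)C)ccc1=O`: 26.3%
compound 2, `C/N=C(\S)NCCCCCn1nc(-c2ccccc2)ccc1=O`: 68.9%
compound 3, `C#CCN/C(=N/CCCCn1nc(-c2ccccc2)ccc1=O)NC#N`: -12.9%

In a functional assay on the whole organism with Rattus norvegicus as the target, at a dose of 100 mg/kg (a lower number here means less inhibition, a higher number more inhibition at the dose given (going by the name of the read-out)), compound 1 stands second highest of the three numbers. Its nearest neighbour is compound 3, whose value lies well below it, beyond the scatter; furthest is compound 2, whose value lies far above, also beyond the scatter. Compound 4, `C/N=C(/NC#N)NCCCCn1nc(N2CCN(C)CC2)ccc1=O`, differs from compound 1 in one place: 4-methylpiperazin-1-yl in place of dimethylamino on an aromatic carbon. Going by the values given here, no pair of measured compounds differing in a single place is available, so the size of this step is unknown. The expected step is a number 5.7 percentage points higher from compound 1 to compound 4 (within the scatter), a shift in the upward direction that stays within the usual scatter. For compound 4 the estimated value is 32%, with a range from 0% to 62%.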

Compound 4, a percentage reported as inhibition, in the whole organism at one dose (the size of the read-out at that dose, not a potency): 7.9%
For compound 4 the middle estimate is 24.1 percentage points above the measured one, within the range that was stated.
By their numbers in this assay, from the lowest: compound 3; then compound 4; then compound 1; then compound 2.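

In this assay, going by these compounds alone, replacing dimethylamino with 4-methylpiperazin-1-yl on this aromatic carbon gives a number 18.4 percentage points lower from compound 1 to compound 4 (beyond the scatter) and is the first single change that can be read here. The step shows that the group at this position affects the inhibition seen in the whole animal. On this core, with this chain and side group kept the same, the six-membered ring does not improve on dimethylamino.

From the compounds shown here alone, whether a morpholine or piperidine ring here would give a similar drop remains open. Nothing available explains the drop.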